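The compounds below may be only part of what the source reports. "The series", "measured", "known", "first", "only" and "open" are said of these compounds alone.

Compound 1 `CN(C)CN1C(=O)C(=O)c2c(Br)cccc21`: 77900 nM in an ADME assay on 184B5 cells (Homo sapiens) for cytotoxicity, read by sulforhodamine B assay, with a stated time of 48 h; on this read-out higher numbers stand for weaker inhibition of growth and lower numbers for stronger inhibition of growth
Compound 2 `CCN(CC)CN1C(=O)C(=O)c2c(Br)cccc21`: 172000 nM in this assay

Compound 2 stands highest of these two numbers, set apart by a 2.2-fold higher number from compound 1 to compound 2 (0.34 log units; beyond the scatter). Compound 3 `CCN(CC)CN1C(=O)C(=O)c2c(Cl)cccc21` differs from compound 2 by chloro in place of bromo on an aromatic carbon. Among the compounds with values here, no measured step swaps one halogen for another; the only step known, a 2.2-fold higher number from compound 1 to compound 2 (0.34 log units; beyond the scatter), concerns the amine and cannot simply be carried over to this change. Within the data shown here, with no comparable step to lean on, no shift beyond the scatter is expected, and compound 3 is estimated at 190000 nM, with a range from 80000 nM to 450000 nM, which means an expected step of a 1.1-fold higher number from compound 2 to compound 3 (0.04 log units; within the scatter).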

Compound 3, concentration for 50% growth inhibition: 22500 nM
Beside the measured number, compound 3's estimate is 8.4-fold (0.93 log units) above it, and the stated range ends above it.
By their numbers in this assay, from the lowest: compound 3; then compound 1; then compound 2.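

The aromatic carbon that carries the halogen clearly matters in this assay: with the diethylamino group held fixed, chloro in place of bromo gives a 7.6-fold lower number from compound 2 to compound 3 (0.88 log units; beyond the scatter) and so strengthens growth inhibition. This halogen swap moves the number further than the amine change did in a 2.2-fold higher number from compound 1 to compound 2 (0.34 log units; beyond the scatter), so the amine is not the only part of these compounds that counts. No measurement at hand gives a reason for this shift. Still open, going by these compounds, is how fluoro or methoxy would behave on this carbon, and whether chloro would give a similar step with dimethylamino on the chain.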